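The compounds below may be only part of what the source reports. "The series", "measured", "known", "first", "only" and "open" are said of these compounds alone.

Working notes on the chain-end series. Compound 3 `CC[N+]1(CCCCCCCOc2cc(C)cc(-n3cc(C(=O)Nc4cc(F)cc(F)c4)c(=O)c4ccc(N(C)C)nc43)c2)CCCCC1` carries a charged end group on the chain that leaves the aromatic ring through an oxygen; in an assay on LX2 cells for inhibition of COL1A1 promoter (Homo sapiens), read by a luciferase reporter, with a stated time of 24 h, tested at 20 uM (a higher number here means a stronger effect of the compound at the concentration tested, a lower number a weaker effect), compound 3 gives 67.2%, the higher of the two numbers recorded so far. Compound 1 `Cc1cc(OCCCCCCC[N+]23CCN(CC2)CC3)cc(-n2cc(C(=O)Nc3cc(F)cc(F)c3)c(=O)c3ccc(N(C)C)nc32)c1` differs from it only in that end group, and in this assay compound 1 gives 10.3%. Compound 2 `CC[N+]1(CCCCCCCOc2ccc(-n3cc(C(=O)Nc4cc(F)cc(F)c4)c(=O)c4ccc(N(C)C)nc43)c(Cl)c2)CCCCC1` changes the substitution of the aromatic ring carrying the chain and has a different end group; in this assay compound 2 is reported as "not active" (no number reported), with no number given. Among the measured compounds shown here, the one measured step at the chain end, a number 56.9 percentage points higher from compound 1 to compound 3 (beyond the scatter), shows that exchanging this group can move the read-out by a large amount. Compound 4 `Cc1cc(OCCCCCCC[N+](C)(C)C2CCCCC2)cc(-n2cc(C(=O)Nc3cc(F)cc(F)c3)c(=O)c3ccc(N(C)C)nc32)c1` is the next exchange at that position: a group of 9 heavy atoms (8 carbon, 1 nitrogen; one six-membered non-aromatic ring of carbon only) in place of a group of 8 heavy atoms (7 carbon, 1 nitrogen; one six-membered non-aromatic ring with 1 hetero atom), on a saturated chain carbon, seven bonds along the chain from an oxygen on an aromatic ring. For the measured compounds named here, no measured step covers this particular exchange, so the direction is uncertain. The step expected for compound 4 is a number 12.2 percentage points lower from compound 3 to compound 4 (beyond the scatter), a modest drop within a wide range. Compound 4 is estimated at 55%, between 25% and 80%.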

Compound 4, a percentage reported as inhibition, at one concentration (the size of the read-out at that concentration, not a potency): 52.5%
Estimate against measurement, compound 4: 2.5 percentage points above; the measured number falls inside the stated range.
By their numbers in this assay, from the lowest: compound 1; then compound 4; then compound 3.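

In this assay the exchange on the saturated chain carbon gives a number 14.7 percentage points lower from compound 3 to compound 4 (beyond the scatter) while the same incoming group gives a number 42.2 percentage points higher from compound 1 to compound 4 (beyond the scatter) against the end group with two rings. The step from compound 3 to compound 4 appears with net charge +1 and the hydrogen-bond donor and acceptor counts unchanged, so these counts alone do not fix the read-out at this position. An end group with a six-membered non-aromatic ring of carbon only therefore stays well clear of compound 1 but does not reach compound 3.

No available measurement explains either step. From the compounds shown here alone, whether a morpholine ring or a longer chain at this place would hold the read-out remains open, as does whether this order of end groups carries over to the chlorine-bearing ring of compound 2.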